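A few compounds are considered here, and "the series" means these few. Any claim that something is new, unique, unknown or untested is made for them only; others in the source may bear on it.

Measured compounds:
- compound 1, `ClCc1ccccc1Cn1cnc2c(Cl)nc(Cl)nc21`: 5620 nM
- compound 2, `ClCc1ccccc1Cn1cnc2c(Cl)ncnc21`: 95500 nM
- compound 3, `ClCc1cccc(Cn2cnc3ncnc(Cl)c32)c1`: 6300 nM

All three compounds were tested in a functional assay on TK-10 cells (Homo sapiens) for cytotoxicity, read by sulforhodamine B assay, with a stated time of 48 h; a lower number here means that less compound is tolerated, a higher number that more compound is tolerated. Compound 2 and compound 1 share a core and differ in one place: chloro in place of hydrogen on an aromatic carbon. This change gave a 17-fold lower number from compound 2 to compound 1 (1.23 log units; beyond the scatter). Compound 3 carries a different arrangement of the same atoms as compound 2; the difference between the two cores is not broken down here. In this assay compound 3 gives 6300 nM, and compound 1 gives 5620 nM, two numbers within the usual scatter of each other, while compound 2 stands far higher.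

Compound 4, `ClCc1cccc(Cn2cnc3nc(Cl)nc(Cl)c32)c1`, has not yet been measured. It differs from compound 3 by chloro in place of hydrogen on an aromatic carbon, the same change that turns compound 2 into compound 1, made at the same place. A number lower than that of compound 3 is therefore expected for compound 4, because the earlier change gave a 17-fold lower number from compound 2 to compound 1 (1.23 log units; beyond the scatter). Since compound 3 already stands close to compound 1, the expected step is set smaller than the earlier one, at a 4.2-fold lower number from compound 3 to compound 4 (0.62 log units; beyond the scatter). For compound 4 a value of about 1500 nM is estimated in this assay, most likely between 300 nM and 6000 nM.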

Compound 4, concentration lethal to 50% of the cells: 55000 nM
Compound 4: middle estimate off by 37-fold (1.56 log units), on the low side; measured number above the stated range.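

In this assay, chloro in place of hydrogen on an aromatic carbon gave an 8.7-fold higher number from compound 3 to compound 4 (0.94 log units; beyond the scatter), a step that runs the opposite way to the one seen on the other core. Set side by side, the two steps clearly disagree: the same change on two cores in this assay, a 17-fold lower number (1.23 log units; beyond the scatter) from compound 2 to compound 1 and an 8.7-fold higher number (0.94 log units; beyond the scatter) from compound 3 to compound 4, 150-fold (2.17 log units) apart, beyond the scatter of two such steps. In this series, then, the result of this change on one core cannot be carried over to the other, not even in direction, but two pairs do not show why the cores respond differently, and they give no rule for any further core.

The compounds shown leave open whether another group at this same place, such as an amine or a bromo group, would follow compound 1 or compound 4 in direction. They also leave open whether the two cores would still part ways if a longer chain stood in place of the chloromethyl group.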